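This account rests on a few compounds, and the source may have more. Where it says the series, first, only, none or still open, it means among the compounds named here.

The study concerns three measured compounds and one that has not yet been tested, all sharing one core. Compound 1 `O=C(/C(=C\c1ccc(I)cc1)Sc1ccc(Br)cc1)c1ccc(Br)cc1`, compound 2 `COc1ccc(C(=O)/C(=C\c2ccc(Cl)cc2)Sc2ccc(F)cc2)cc1` and compound 3 `CN(C)c1ccc(/C=C(/SCc2ccc(F)cc2)C(=O)c2ccc(C(=O)O)cc2)cc1` were run in a functional assay on DU-145 cells (Homo sapiens) for inhibition, read by trypan blue exclusion, with a stated time of 96 h; on this read-out higher numbers stand for weaker inhibition of growth and lower numbers for stronger inhibition of growth. In this assay compound 1 gives 1000 nM, the lowest of the two numbers on record, and compound 3 gives 10000 nM, a gap beyond the usual scatter. Compound 2 reaches only a limit of the assay, > 100000 nM, and no number can be quoted for it (the limit of > 100000 nM in this assay, at which 1 of the 3 values shown sits).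

Compound 4 `O=C(/C(=C\c1ccc(Br)cc1)Sc1ccc(Br)cc1)c1ccc(Br)cc1` is the untested member. It differs from compound 1 in a single place: bromo in place of iodo on an aromatic carbon. The difference, cut one bond further out, reads 4-iodophenyl to 4-bromophenyl, the bromo group standing on an aromatic carbon of a six-membered aromatic ring of carbon only.

Going by the values given here, no pair of measured compounds differing in one place is available here, so there is no measured step to lean on. The expectation is that the swap of one halogen for another at this position changes little, a step in this assay of no more than the scatter, perhaps leaning toward a slightly higher number. The step from compound 1 to compound 4 is therefore expected to be about a 1.5-fold higher number from compound 1 to compound 4 (0.18 log units; within the scatter). Compound 4 is estimated at 1500 nM, with a likely range from 500 nM to 5000 nM.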

Compound 4, concentration for 50% growth inhibition: 1000 nM
For compound 4 the middle estimate is 1.5-fold (0.18 log units) above the measured one; the range from low to high includes it.
By their numbers in this assay, from the lowest: compounds 1 and 4 (each within the scatter of the next); then compound 3. At a limit, above all of these: compound 2.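

In this assay bromo in place of iodo on an aromatic carbon, para to a large group, gives no change at the digits printed from compound 1 to compound 4 (within the scatter) on this read-out. Going by these compounds alone, this is the only measured step between compounds that differ in one place, so it gives the first direct reading at this position: the 4-iodophenyl and 4-bromophenyl forms cannot be told apart here, and this position takes either halogen without a measurable difference in growth inhibition. Nothing on record speaks to what lies behind this outcome.

On these data alone, it remains open whether a nitrile, a trifluoromethyl group or a hydroxyl group at this same place would read like the two halogens or would move the number beyond the scatter. As far as these compounds go, it also remains open whether the exchange of iodo for bromo would give the same reading on a core carrying different groups on its other two aromatic rings, since a single pair of compounds carries this step.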